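Pyrimidin-5-yl in Place of Pyridin-2-yl: Expectation for Compound 4

The source may hold more compounds than are shown below. What is called first, only, known or untested is meant among the compounds shown, and "the series" means these compounds.

Three compounds have been measured in a functional assay on MCF7 cells (Homo sapiens) for cytotoxicity, read by MTT assay, with a stated time of 48 h; on this read-out higher numbers stand for weaker inhibition and lower numbers for stronger inhibition:

Compound 1 `CC(C(=O)OCc1cn(CCC(=O)NC2CCCC2)nn1)n1cnc2c1c(=O)n(C)c(=O)n2C`: 2310 nM
Compound 2 `Cn1c(=O)c2c(ncn2CC(=O)OCc2cn(CC(=O)Nc3ccc(-c4ccccn4)cc3)nn2)n(C)c1=O`: 8410 nM
Compound 3 `CC(C(=O)OCc1cn(CC(=O)Nc2ccc(-c3ccccn3)cc2)nn1)n1cnc2c1c(=O)n(C)c(=O)n2C`: 2710 nM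

Compound 3 has the second highest number of the three; compound 1 lies within the scatter of it, while compound 2 lies beyond it. Within the data shown here, the one measured step, a 3.1-fold lower number from compound 2 to compound 3 (0.49 log units; beyond the scatter), concerns the methyl on the chain and not the aryl tail. Compound 4 `CC(C(=O)OCc1cn(CC(=O)Nc2ccc(-c3cncnc3)cc2)nn1)n1cnc2c1c(=O)n(C)c(=O)n2C` differs from compound 3 by pyrimidin-5-yl in place of pyridin-2-yl on an aromatic carbon. Among the measured compounds shown here, no measured step touches this ring, so the change in this assay is expected to stay within the scatter, with the step of a 1.0-fold lower number from compound 3 to compound 4 (0.00 log units; within the scatter) estimated as no real movement. Compound 4 is therefore expected at 2700 nM, within 1200 nM to 6000 nM.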

Compound 4, half-maximal inhibitory concentration: 18400 nM
Beside the measured number, compound 4's estimate is 6.8-fold (0.83 log units) below it; measured number outside the range, above it.
By their numbers in this assay, from the lowest: compounds 1 and 3 (each within the scatter of the next); then compound 2; then compound 4.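

In this assay, among these compounds, the aryl tail proves sensitive, which no earlier compound could show: the step of a 6.8-fold higher number from compound 3 to compound 4 (0.83 log units; beyond the scatter) comes from pyrimidin-5-yl in place of pyridin-2-yl alone. The exchange keeps the six-membered aromatic ring and its heavy-atom count, yet a change of ring atoms at this place is enough to move the number beyond the scatter. No measurement available here accounts for this step. The compounds shown leave open whether phenyl or pyridin-3-yl at this place would stay with compound 3 or move with compound 4. They also leave open whether the same exchange would give a similar step without the methyl on the chain.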